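A few compounds are considered here, and "the series" means these few. Any claim that something is new, unique, unknown or untested is made for them only; others in the source may bear on it.

Measured so far in an ADME assay on L02 cells (Homo sapiens) for cytotoxicity, read by MTT assay, with a stated time of 24 h; a lower number here means that less compound is tolerated, a higher number that more compound is tolerated:
- compound 1 `Cc1cccc(-n2cc(-c3cccc(NS(=O)(=O)c4c[nH]c(=O)[nH]c4=O)c3)nn2)c1`: 28300 nM
- compound 2 `Cc1ccc(-n2cc(-c3cccc(NS(=O)(=O)c4c[nH]c(=O)[nH]c4=O)c3)nn2)cc1`: 23100 nM
- compound 3 `Cc1cccc(-n2cc(-c3ccc(NS(=O)(=O)c4c[nH]c(=O)[nH]c4=O)cc3)nn2)c1`: 39000 nM

Compound 2 differs from compound 1 by 4-methylphenyl in place of 3-methylphenyl on an aromatic nitrogen and this gave a 1.2-fold lower number from compound 1 to compound 2 (0.09 log units; within the scatter). The difference between the core of compound 1 and the core of compound 3 is not broken down here; the values of compound 1 and compound 3 lie within the scatter of each other, as do those of compound 2 and compound 3.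

Compound 4 `Cc1ccc(-n2cc(-c3ccc(NS(=O)(=O)c4c[nH]c(=O)[nH]c4=O)cc3)nn2)cc1` is not yet measured. It differs from compound 3 by 4-methylphenyl in place of 3-methylphenyl on an aromatic nitrogen, the same change, at the same place, as from compound 1 to compound 2. Resting on compound 1 and compound 2 with a 1.2-fold lower number from compound 1 to compound 2 (0.09 log units; within the scatter), the step to compound 4 is expected to be small, within the scatter: a 1.2-fold lower number from compound 3 to compound 4 (0.07 log units; within the scatter). Compound 4 is therefore estimated at 33000 nM in this assay, with a range from 17000 nM to 65000 nM.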

Compound 4, half-maximal cytotoxic concentration: "not toxic" (no number reported)
Compound 4 has no reported number here; no gap can be computed for the estimate.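

Going by these compounds alone, compound 4 is reported in this assay only as "not toxic", without a number, so no step from compound 3 to compound 4 can be read. The compounds shown leave open how far 4-methylphenyl in place of 3-methylphenyl shifts the number on the core of compound 3. No evidence bearing on this result is available.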